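A few compounds are considered here, and "the series" means these few. Any claim that something is new, unique, unknown or untested is made for them only; others in the source may bear on it.

- Compound 1 `FC(F)(F)c1nccc(N[C@H]2CC[C@@H](Nc3ccc4nnc(Br)n4n3)CC2)n1`: < 3 mL.min-1.g-1 (a limit)
- Compound 2 `CSc1nnc2ccc(N[C@H]3CC[C@@H](Nc4ccnc(C(F)(F)F)n4)CC3)nn12`: 29 mL.min-1.g-1
- Compound 3 `FC(F)(F)c1nccc(N[C@H]2CC[C@@H](Nc3ccc4nnc(C5CC5)n4n3)CC2)n1`: < 3 mL.min-1.g-1 (a limit)

All three values come from an ADME assay on microsomes from liver (Homo sapiens) for metabolic stability, read by LC-MS; a higher number here means faster removal of the compound, a lower number slower removal. Compound 3 stands at < 3 mL.min-1.g-1, which is a limit and not a number. Compound 4 `Nc1nnc2ccc(N[C@H]3CC[C@@H](Nc4ccnc(C(F)(F)F)n4)CC3)nn12` differs from it in one place, with amino in place of cyclopropyl on an aromatic carbon. Three measured steps change that same place. They are an at least 9.6-fold higher number from compound 1 to compound 2 (0.98 log units; beyond the scatter), an at least 9.6-fold lower number from compound 2 to compound 3 (0.98 log units; beyond the scatter) and a step that the two limits leave unreadable from compound 1 to compound 3. Of these three compounds, only compound 2 stands clear of the limit, and amino has not been measured there. No change beyond the scatter is therefore expected, and the expected step is a number no lower from compound 3 to compound 4 (the limit leaves the size open). For compound 4 the estimated value is 3 mL.min-1.g-1, with an expected range of 1.5 mL.min-1.g-1 to 10 mL.min-1.g-1.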

Compound 4, intrinsic clearance in microsomes: < 3 mL.min-1.g-1
Compound 4 gave a limit, no number (the forecaster's own chance of this, stated with the estimate: 60%); the middle value lies on the limit itself.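

In this assay, the result for compound 4 is a limit and not a number, so amino joins bromo and cyclopropyl at this position. Methylsulfanyl remains the only group shown that stands clear of that limit, with an at least 9.6-fold lower number from compound 2 to compound 4 (0.98 log units; beyond the scatter). The steps linking compound 4 to compound 1 and compound 3 cannot be read, since all three compounds sit at the same limit: the limit of < 3 mL.min-1.g-1 in this assay, at which 3 of the 4 values shown sit.

Going by these compounds, how bromo, cyclopropyl and amino truly rank remains open. So does whether methoxy or ethylsulfanyl on this carbon would behave like methylsulfanyl.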